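Swapping Iodo for Fluoro in a Calpain-1 Inhibitor Pair

A few compounds are considered here, and "the series" means these few. Any claim that something is new, unique, unknown or untested is made for them only; others in the source may bear on it.

Measured so far:
compound 1 `O=C(O)/C(S)=C/c1c[nH]c2cc(Br)ccc12`: 90 nM
compound 2 `O=C(O)/C(S)=C/c1ccc(I)cc1`: 5200 nM

Of the compounds shown here, two have been measured in an assay on isolated protein for inhibition of Calpain-1 catalytic subunit (Sus scrofa); on this read-out higher numbers stand for weaker inhibition and lower numbers for stronger inhibition. Compound 1 gives 90 nM, while compound 2 gives 5200 nM, the higher of the two numbers, with a gap to compound 1 that lies beyond the usual scatter. Compound 3 `O=C(O)/C(S)=C/c1ccc(F)cc1` differs from compound 2 by fluoro in place of iodo on an aromatic carbon. Going by the values given here, no measured pair shows this change, so the expectation rests on compound 2 alone. The expected step of a 1.9-fold higher number from compound 2 to compound 3 (0.28 log units; within the scatter) is modest, toward a higher number, and may fall within the scatter. Compound 3 is expected to give about 10000 nM, between 3000 nM and 40000 nM.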

Compound 3, half-maximal inhibitory concentration: 5600 nM
The estimate for compound 3 lay 1.8-fold (0.25 log units) above the measured number, and the stated range covers the measured number.
By their numbers in this assay, from the lowest: compound 1; then compounds 2 and 3 (each within the scatter of the next).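

In this assay, going by these compounds alone, fluoro in place of iodo on an aromatic carbon gives a 1.1-fold higher number from compound 2 to compound 3 (0.03 log units; within the scatter), the first step here that isolates a change at one place. At this position, para to a group of 6 heavy atoms, the read-out does not separate these two substituents. Nothing available here bears on the reason for this result.

From the compounds shown here alone, whether an amine or a methoxy group at this position would move the number stays open. So does whether the same swap would behave alike on the core of compound 1.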